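Shortening a side chain across two related cores

The source may hold more compounds than are shown below. What is called first, only, known or untested is meant among the compounds shown, and "the series" means these compounds.

Compound 1 `O=C(CN(c1ncnc2c1ncn2C1CCCCO1)C1CC1)NCC(=O)OCc1ccccc1`, compound 2 `NC(=O)C[C@H](NC(=O)CN(c1ncnc2c1ncn2C1CCCCO1)C1CC1)C(=O)OCc1ccccc1` and compound 3 `NC(=O)CC[C@H](NC(=O)CN(c1nc(Cl)nc2[nH]cnc12)C1CC1)C(=O)O` were tested in a functional assay on the whole organism (Tail, strain ICR) with Mus musculus as the target, in the tail flick test, with a stated time of 30 min, at a dose of 25 umol/kg by the oral route; a higher number here means a stronger effect of the compound at the dose given, a lower number a weaker effect. Compound 1 gives 55.7%, compound 2 gives 34.5% and compound 3 gives 33.1%, with compound 2 and compound 3 lying within the scatter of each other. Compound 1 arises from compound 2 by hydrogen in place of carbamoylmethyl on a saturated chain carbon bound to an amide-type nitrogen and a carbonyl carbon, a step of a number 21.2 percentage points higher from compound 2 to compound 1 (beyond the scatter). Compound 4 `C[C@H](NC(=O)CN(c1nc(Cl)nc2[nH]cnc12)C1CC1)C(=O)O` is not yet measured and arises from compound 3 by hydrogen in place of carbamoylmethyl on a saturated chain carbon, two bonds along the chain from an amide-type nitrogen and a carbonyl carbon. The difference between the two cores of compound 2 and compound 3 is not broken down here. The change is the same kind of change, yet the place differs: in compound 2 the carbon is bound to an amide-type nitrogen and a carbonyl carbon, whereas in compound 3 it is two bonds along the chain from them. Because a number 21.2 percentage points higher from compound 2 to compound 1 (beyond the scatter) was modest and both core and place differ, a smaller rise is expected, a number 11.9 percentage points higher from compound 3 to compound 4 (beyond the scatter). Compound 4 is thus estimated to give 45% in this assay, between 28% and 62%.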

Compound 4, a percentage reported as activity, at one dose (the size of the read-out at that dose, not a potency): 48.1%
For compound 4 the middle estimate is 3.1 percentage points below the measured one; the measured number falls inside the stated range.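

In this assay, hydrogen in place of carbamoylmethyl gives a number 15 percentage points higher from compound 3 to compound 4 (beyond the scatter). The change raises the read-out on both cores, and the two rises agree as closely as repeated measurements would: the same change on two cores in this assay, a number 21.2 percentage points higher (beyond the scatter) from compound 2 to compound 1 and a number 15 percentage points higher (beyond the scatter) from compound 3 to compound 4, 6.2 percentage points apart, within the scatter of two such steps. Going by these compounds alone, with only two pairs, which also differ in the place of the change, this does not show whether core or place has any influence on the step, nor that the change would give a similar rise on any other core.

The compounds shown leave open what an amine or a longer chain of plain carbons would give in place of carbamoylmethyl. They also leave open whether a hydroxymethyl group would behave like the hydrogen or like the carbamoylmethyl.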